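The source may report more compounds than this note shows. Statements on the series, on what has been measured and on what is new or still open speak of the compounds shown alone.

Of the compounds shown here, three that share one core have been tested for their effect on human cells in an ADME assay on cells (Homo sapiens) for cytotoxicity; on this read-out lower numbers stand for higher toxicity in this test and higher numbers for lower toxicity in this test. Compound 1 has the structure `CCC1=C(C(=O)OCC2CCCCC2)[C@H](c2cccc(O)c2)NC(=O)N1`. In this assay compound 1 reaches only a limit of the measurement, > 10000 nM. Compound 2 has the structure `CCC1=C(C(=O)OCC2CCCCC2)[C@H](c2ccc(O)c(Cl)c2)NC(=O)N1`. For compound 2 this assay likewise reports only a limit, > 10000 nM. Compound 3 has the structure `O=C1NC2=C(C(=O)OC2)C(c2cccc(O)c2)N1`. Compound 3 also stops at a limit in this assay, > 10000 nM. Among the measured compounds shown here, compound 2 thus stands where every value so far stands, namely at the limit of > 10000 nM in this assay, at which 3 of the 3 values shown sit. For the measured compounds named here, the only step between measured compounds is a step that the two limits leave unreadable from compound 1 to compound 2; the two limits hide its size.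

Compound 4, with the structure `CCC1=C(C(=O)CCC2CCCCC2)[C@H](c2ccc(O)c(Cl)c2)NC(=O)N1`, differs from compound 2 by 2-cyclohexylethyl in place of cyclohexylmethoxy on a carbonyl carbon. Going by the values given here, no measured step bears on this change, and the one known step has no readable size, so nothing points in either direction. Compound 4 is therefore expected to remain at the limit as well, an estimated 15000 nM with a range from 5000 nM to 50000 nM. The step this estimate means, a step that the limit leaves unreadable from compound 2 to compound 4, is expected to be none beyond the scatter.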

Compound 4, half-maximal cytotoxic concentration: > 10000 nM
Compound 4 was reported as a limit; the forecaster's own chance of this, stated with the estimate: 70%; the middle value does not contradict the limit.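

In this assay compound 2 and compound 4 both reach only a limit, and the step between them cannot be read. The compounds shown leave open at what concentration any of them harms these cells, and whether 2-cyclohexylethyl and cyclohexylmethoxy differ at all.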